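The compounds below may be only part of what the source reports. "The series", "measured", "known", "first", "only" and "open" are said of these compounds alone.

Series notes. In a functional assay on MV4-11 cells (Homo sapiens) for antiproliferative activity, read by CCK-8 assay, with a stated time of 72 h (a higher number here means a weaker inhibitor, a lower number a stronger inhibitor), compound 1 `Cn1cc(-c2ccccc2F)c2cc(C(=O)NCc3ccc(C(=O)Nc4ccccc4N)cc3)[nH]c2c1=O` gives 230 nM, compound 2 `Cn1cc(-c2ccccc2Oc2ccccc2)c2cc(C(=O)NCCCC(=O)NO)[nH]c2c1=O` gives 380 nM and compound 3 `Cn1cc(-c2ccccc2Oc2ccccc2)c2cc(C(=O)NCCCCCCC(=O)NO)[nH]c2c1=O` gives 180 nM. Compound 3 holds the lowest of the three numbers: compound 2 stands beyond the scatter from it, compound 1 within it, so no order between compound 3 and compound 1 is claimed. Among the compounds with values here, the only single-change step measured, a 2.1-fold lower number from compound 2 to compound 3 (0.32 log units; beyond the scatter), concerns chain length alone. Compound 4 `Cn1cc(-c2ccccc2Oc2ccccc2)c2cc(C(=O)NCCCCCCC(=O)Nc3ccccc3N)[nH]c2c1=O` differs from compound 3 by 2-aminophenyl in place of hydroxy on an amide-type nitrogen. Within the data shown here, compound 1 also carries (2-aminophenyl)carbamoyl, yet no single-change step links it to compound 3; their two values sit within the scatter of each other. Among the measured compounds shown here, no measured step bears on this change, so in this assay no step beyond the scatter is expected, a 1.4-fold higher number from compound 3 to compound 4 (0.14 log units; within the scatter). Compound 4 is therefore estimated at 250 nM, range 100 nM to 800 nM.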

Compound 4, half-maximal inhibitory concentration: 130 nM
For compound 4 the middle estimate is 1.9-fold (0.28 log units) above the measured one, and the stated range covers the measured number.
By their numbers in this assay, from the lowest: compounds 4, 3, 1 and 2 (each within the scatter of the next, the first and the last beyond it).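

In this assay, 2-aminophenyl in place of hydroxy on an amide-type nitrogen gives a 1.4-fold lower number from compound 3 to compound 4 (0.14 log units; within the scatter), so hydroxycarbamoyl and (2-aminophenyl)carbamoyl cannot be told apart on this chain. Within the data shown here, the only earlier step concerned chain length; this one gives a first reading at the end group itself. No measurement at hand accounts for this result.

As far as these compounds go, whether the same exchange reads alike on the chain of compound 2 stays open. Also open, from the compounds shown here alone, is how a carboxylic acid at this position, or a longer chain carrying either end group, would read.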